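The compounds below may be only part of what the source reports. "The series", "measured", "known", "first", "only" and "open" are said of these compounds alone.

Three compounds have been measured in a functional assay on CCRF-CEM cells (Homo sapiens) for inhibition; a lower number here means a stronger inhibitor, a higher number a weaker inhibitor:

compound 1 `O=C1/C(=C/c2ccccc2Br)CCCc2ccccc21` gives 32100 nM
compound 2 `O=C1/C(=C/c2ccccc2Cl)CCCc2ccccc21` gives 18400 nM
compound 3 `COc1ccccc1/C=C1\CCCc2ccccc2C1=O` gives 28900 nM

Compound 3 has the second highest of these three numbers; its nearest neighbour is compound 1 and its furthest is compound 2, and both of those gaps lie within the scatter. The next compound, compound 4 `O=C1/C(=C/c2ccccc2F)CCCc2ccccc21`, differs from compound 3 in one place: fluoro in place of methoxy on an aromatic carbon. For the measured compounds named here, the steps that bear on this are the two earlier swaps of a halogen for methoxy, a 1.1-fold lower number from compound 1 to compound 3 (0.05 log units; within the scatter) and a 1.6-fold higher number from compound 2 to compound 3 (0.20 log units; within the scatter), neither of which moved beyond the scatter. A swap back to a halogen is therefore expected to give no step beyond the scatter in this assay, which is the meaning of a 1.1-fold lower number from compound 3 to compound 4 (0.05 log units; within the scatter). Compound 4 is estimated at 26000 nM, within 11000 nM to 60000 nM.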

Compound 4, half-maximal inhibitory concentration: 28200 nM
The estimate for compound 4 lay 1.1-fold (0.04 log units) below the measured number; the range from low to high includes it.
By their numbers in this assay, from the lowest: compounds 2, 4, 3 and 1 (each within the scatter of the next).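

In this assay, fluoro on an aromatic carbon ortho to a large group stays within the scatter of all three other groups tested there, methoxy (a 1.0-fold lower number from compound 3 to compound 4 (0.01 log units; within the scatter)), chloro (a 1.5-fold higher number from compound 2 to compound 4 (0.19 log units; within the scatter)) and bromo (a 1.1-fold lower number from compound 1 to compound 4 (0.06 log units; within the scatter)). Replacing methoxy with fluoro also removes the hydrogen-bond acceptor counted for methoxy, and the number does not move beyond the scatter. No evidence is available to explain this result.

As far as these compounds go, whether an amine, a carboxylic acid or a longer chain at this place would move the number beyond the scatter remains open. So does whether these four groups would read alike elsewhere on the ring.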